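Replacing 2-aminoethyl in compound 3 with isopropoxy

The source may report more compounds than this note shows. Statements on the series, on what has been measured and on what is new or still open speak of the compounds shown alone.

In a functional assay on WI-38 VA13 cells (Homo sapiens) for cytotoxicity (a higher number here means that more compound is needed for the effect, a lower number that less compound is needed), compound 3 `NCCC(=O)Nc1nc2ccc(NC(=O)c3c(Cl)cccc3Cl)cc2s1` gives 5.3 ug/mL, the highest of the three numbers. Compound 1 `O=C(Nc1ccc2nc(NC(=O)C3CCCCC3)sc2c1)c1c(Cl)cccc1Cl` stands at 0.015 ug/mL and compound 2 `O=C(Nc1ccc2nc(NC(=O)C3CC3)sc2c1)c1c(Cl)cccc1Cl` at 0.013 ug/mL.

Compound 4 `CC(C)OC(=O)Nc1nc2ccc(NC(=O)c3c(Cl)cccc3Cl)cc2s1` carries isopropoxy in place of 2-aminoethyl on a carbonyl carbon.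

Within the data shown here, two measured steps bear directly on this change, a 350-fold higher number from compound 1 to compound 3 (2.55 log units; beyond the scatter) and a 410-fold higher number from compound 2 to compound 3 (2.61 log units; beyond the scatter), and both are large. The swap of cyclohexyl for cyclopropyl, a 1.2-fold lower number from compound 1 to compound 2 (0.06 log units; within the scatter), stays within the scatter, so two quite different groups without the amine give matching values. Among the measured compounds shown here, no measured compound carries isopropoxy, so the transfer from those two groups is uncertain, and the range is left wider on the upper side.

The step expected in this assay is large and towards a lower number, an estimated 180-fold lower number from compound 3 to compound 4 (2.25 log units; beyond the scatter). For compound 4 the estimate is 0.03 ug/mL, with an expected range of 0.008 ug/mL to 0.3 ug/mL.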

Compound 4, half-maximal effective concentration: 0.0026 ug/mL
The estimate for compound 4 lay 12-fold (1.06 log units) above the measured number; the measured number lies below the stated range.
By their numbers in this assay, from the lowest: compound 4; then compounds 2 and 1 (each within the scatter of the next); then compound 3.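

In this assay, among these compounds, the group on this carbonyl carbon can do more than the earlier compounds showed: a 2000-fold lower number from compound 3 to compound 4 (3.31 log units; beyond the scatter) is a large step, and it does more than undo the 2-aminoethyl effect. Among the groups without an amine, the number still moves, with a 5.0-fold lower number from compound 2 to compound 4 (0.70 log units; beyond the scatter) and a 5.8-fold lower number from compound 1 to compound 4 (0.76 log units; beyond the scatter) both beyond the scatter, whereas cyclohexyl and cyclopropyl had matched within it, and compound 4 now has the lowest number of the four. Nothing available gives a reason for these steps.

The compounds shown do not separate the oxygen link of isopropoxy from its branched carbons, which an ethoxy, a tert-butoxy or an isopropyl group on the same carbonyl would address. They also leave open whether the high number of compound 3 follows the amine itself, which a 2-hydroxyethyl group could test.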